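A bigger aryl ether in place of trifluoromethoxy

A few compounds are considered here, and "the series" means these few. Any claim that something is new, unique, unknown or untested is made for them only; others in the source may bear on it.

Compound 1 `CCOC(=O)c1c(-c2cccc(OC(F)(F)F)c2)[nH]c2cc(OC)ccc2c1=O` carries a trifluoromethoxy group on its pendant ring. In an ADME assay on HepG2 cells (Homo sapiens) for cytotoxicity, read by luminescence, with a stated time of 72 h (a higher number here means that more compound is needed for the effect, a lower number that less compound is needed), compound 1 gives only a limit, > 21500 nM. Compound 2 `CCOC(=O)c1c(-c2cccc(OC(F)(F)F)c2)[nH]c2cc(OC)c(F)cc2c1=O` adds a fluoro in place of hydrogen on an aromatic carbon; in this assay compound 2 likewise reaches only a limit, > 21500 nM. The step that the two limits leave unreadable from compound 1 to compound 2 is therefore unreadable, since (the limit of > 21500 nM in this assay, at which 2 of the 2 values shown sit). Compound 3 `CCOC(=O)c1c(-c2cccc(Oc3c(C)cccc3C)c2)[nH]c2cc(OC)c(F)cc2c1=O` differs from compound 2 by 2,6-dimethylphenyl in place of trifluoromethyl on an oxygen on an aromatic ring. With both measured values sitting at a limit, no readable step guides the change, so compound 3 is expected to stay at or beyond that limit. Compound 3 is estimated at 25000 nM, in a range from 8000 nM to 60000 nM. That estimate means an expected step that the limit leaves unreadable from compound 2 to compound 3.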

Compound 3, half-maximal effective concentration: > 21500 nM
Compound 3: only a limit was reported (the forecaster's own chance of this, stated with the estimate: 70%); the middle value is on the limit's open side.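

The step from compound 2 to compound 3 cannot be read, since each gives only a limit: the limit of > 21500 nM in this assay, at which 3 of the 3 values shown sit.

The compounds shown leave open at what concentration any of the three reaches a half-maximal effect in this assay, and so whether either change shifts it.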